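The source may hold more compounds than are shown below. What is called first, only, known or untested is meant among the compounds shown, and "the series" means these compounds.

Of the compounds shown here, three have numbers so far in a physicochemical assay for lipophilicity; a higher number here means a more lipophilic compound, a lower number a more polar compound. Compound 1 `O=C1/C(=C/c2ccc(F)cc2)CCC/C1=C\c1ccccc1[N+](=O)[O-]` gives 4.86, and compound 3 `CN(C)c1ccc(/C=C2\CCC/C(=C\c3cccc([N+](=O)[O-])c3)C2=O)cc1` gives 5. Compound 2 `COc1cc(/C=C2\CCC/C(=C\c3ccccc3[N+](=O)[O-])C2=O)cc(OC)c1OC` stands lowest of the three at 4.33, and both of the other numbers lie higher, beyond the scatter.

The compound still awaiting measurement is compound 4 `COc1cc(/C=C2\CCC/C(=C\c3ccc([N+](=O)[O-])cc3)C2=O)cc(OC)c1OC`, which departs from compound 2 in a single place: 4-nitrophenyl in place of 2-nitrophenyl on a double-bonded chain carbon bound to a double-bonded ring carbon. It carries 4-nitrophenyl in place of 2-nitrophenyl on a double-bonded chain carbon bound to a double-bonded ring carbon, so the two compounds have the same atoms, joined differently.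

Within the data shown here, no pair of measured compounds isolates a change of this kind, so the data offer no direct guide to its size. The expectation therefore starts from compound 2 at 4.33, with the counts of atoms, rings, donors and acceptors unchanged. The step expected in this assay is a number 0.12 log units higher from compound 2 to compound 4 (within the scatter), slightly upward and not beyond the scatter. For compound 4 the estimated value is 4.45, with an expected range from 4.1 to 4.8.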

Compound 4, partition coefficient: 4.56
Estimate against measurement, compound 4: 0.11 log units below; the measured number falls inside the stated range.
By their numbers in this assay, from the lowest: compounds 2, 4, 1 and 3 (each within the scatter of the next, the first and the last beyond it).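

In this assay the swap of 2-nitrophenyl for 4-nitrophenyl, on a double-bonded chain carbon bound to a double-bonded ring carbon, gives a number 0.23 log units higher from compound 2 to compound 4 (within the scatter) and so leaves the two compounds indistinguishable. Among these compounds, this is the first pair that differ in one place, and it shows that at this position, with the rest of the structure held constant, relocating the nitro group on the phenyl ring produces no step that can be told from the scatter. The earlier compounds could not show this, as each differed from the others in more than one place, and nothing available here accounts for the result in structural terms.

On these data alone, whether the same swap would read the same way on the core of compound 1 or compound 3 remains open, as a single pair speaks only for the core it shares. The compounds shown also leave open what a group of a different kind would do at this place, such as a phenyl ring carrying a carboxylic acid or a primary amine in place of the nitro group.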